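The compounds below may be only part of what the source reports. "The series", "measured", "known", "first", "only" and "open" are said of these compounds alone.

Measured so far in a physicochemical assay for solubility, at pH 7.4; on this read-out lower numbers stand for lower solubility and higher numbers for higher solubility:
compound 1, `Cc1cc(Cl)c(-c2cn(C)cn2)cc1NC(=O)c1ccc(OCc2ccccn2)cc1`, gives 20000 nM
compound 2, `Cc1ccc(-c2nccn2C)cc1NC(=O)c1ccc(OCc2ccccn2)cc1`, gives 192000 nM
compound 3, `Cc1csc(-c2cc(NC(=O)c3ccc(OCc4ccccn4)cc3)c(C)cc2C)n1`, gives only a limit, < 1000 nM

Compound 3 stands apart from the other two. In this assay compound 3 is reported only as a limit, < 1000 nM, and not as a number. This is the limit of < 1000 nM in this assay, at which 1 of the 3 values shown sits. Compound 1 and compound 2 each carry a different five-membered ring on the shared core and each has a measured number, with compound 2 at 192000 nM and compound 1 at 20000 nM.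

Compound 4, `Cc1cc(C)c(-c2cccc(N)n2)cc1NC(=O)c1ccc(OCc2ccccn2)cc1`, is not yet measured. It differs from compound 3 in one place: 6-aminopyridin-2-yl in place of 4-methyl-1,3-thiazol-2-yl on an aromatic carbon. The group that enters brings one hydrogen-bond donor where the group that leaves has none, and a six-membered ring where the leaving group has a five-membered one.

Within the data shown here, no step between measured compounds is known, so the size of this change in this assay cannot be read from a neighbouring pair. Compared with the limit of compound 3, a rise beyond the usual scatter is expected for the step of an at least 4.0-fold higher number from compound 3 to compound 4 (0.60 log units; beyond the scatter). Compound 4 is therefore estimated at about 4000 nM, within a range from 800 nM to 25000 nM.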

Compound 4, solubility: 2000 nM
The estimate for compound 4 lay 2.0-fold (0.30 log units) above the measured number, and the stated range covers the measured number.
By their numbers in this assay, from the lowest: compound 4; then compound 1; then compound 2. At a limit, below all of these: compound 3.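

In this assay compound 4 gives 2000 nM as a measured number, so the core of compound 3 now has a real value with 6-aminopyridin-2-yl on this aromatic carbon, ortho to a methyl group and para to a methyl group. Compound 3 gives < 1000 nM which is a limit and not a number. On these data alone, the change therefore reads only as an at least 2.0-fold higher number from compound 3 to compound 4 (0.30 log units; that floor lies within the scatter) and its true size stays unknown because one end of the step rests on a limit: the limit of < 1000 nM in this assay, at which 1 of the 4 values shown sits.

This single pair changes the ring size and adds the amine together, so it cannot say which of the two matters, and a plain pyridin-2-yl group without the amine, or a carboxylic acid on the same ring, would be needed to pull these apart. As far as these compounds go, compound 1 and compound 2 differ from compound 4 in more than one place, so no steps can be read from them, and how a five-membered ring with an amine would behave on this core also stays open.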